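The source may report more compounds than this note shows. Statements on the series, on what has been measured and on what is new or still open speak of the compounds shown alone.

Of the compounds shown here, two have so far been tested in a functional assay, with a stated time of 30 min; a lower number here means a stronger inhibitor, a higher number a weaker inhibitor. Compound 1 `COc1cccc(/C=N/c2ccc(OCc3ccccc3)cc2)c1O` returns only a limit of the assay, > 200000 nM, and not a number. Among the measured compounds shown here, compound 2 `Oc1ccc(O)c(/C=N/c2ccc(OCc3ccccc3)cc2)c1` gives 21300 nM in this assay, and this is the only actual number among the values obtained. The other entry, that of compound 1, is a limit (the limit of > 200000 nM in this assay, at which 1 of the 2 values shown sits). Compound 2 therefore stands alone as the measured reference point of the set.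

The next compound, compound 3 `Oc1ccccc1/C=N/c1ccc(OCc2ccccc2)cc1`, differs from compound 2 in one place: hydrogen in place of hydroxy on an aromatic carbon. For the measured compounds named here, because no pair of measured compounds differs in a single place, there is no measured step to show how large a change of this kind tends to be in this assay. The expectation here rests on compound 2 alone and on the loss of one hydroxy. In this assay the step is expected to be a 2.8-fold higher number from compound 2 to compound 3 (0.45 log units; beyond the scatter), a move toward weaker inhibition that goes beyond the usual scatter. Compound 3 is estimated at 60000 nM, with a plausible range from 15000 nM to 200000 nM.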

Compound 3, half-maximal inhibitory concentration: > 200000 nM
Compound 3 was reported as a limit; the forecaster's own chance of this, stated with the estimate: 25%; middle value at least 3.3-fold (0.52 log units) from the limit.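

In this assay, removing the hydroxy group that sits para to a hydroxy group, which turns 2,5-dihydroxyphenyl into 2-hydroxyphenyl, gives an at least 9.3-fold higher number from compound 2 to compound 3 (0.97 log units; beyond the scatter), so this single group on the ring clearly matters for the inhibition that compound 2 shows. Compound 3 gives > 200000 nM, which is a limit of the assay and not a number. The step therefore has a known minimum size but no known full size, because only compound 2 has an actual number in this set: the limit of > 200000 nM in this assay, at which 2 of the 3 values shown sit.

The step from compound 1 to compound 3 joins two limits and cannot be read, so hydrogen and methoxy on that ring carbon cannot be ranked against each other. Among the compounds shown here, it also remains open whether the hydroxy group of compound 2 is the only group that works at its place, or whether an amine or a carboxylic acid on the same aromatic carbon would give a number close to that of compound 2 or one closer to the limit.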